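Swapping the Amide Aryl Group: Compound 3 to Compound 4

A few compounds are considered here, and "the series" means these few. Any claim that something is new, unique, unknown or untested is made for them only; others in the source may bear on it.

Of the compounds shown here, three sharing one core have been measured in a functional assay on HCC1937 cells (Homo sapiens) for antiproliferative activity, read by CCK-8 assay, with a stated time of 72 h; a lower number here means a stronger inhibitor, a higher number a weaker inhibitor. Compound 1 `Cc1ccc(C(=O)Nc2cccc(-c3oc4cc(-c5ccc(F)cc5)ccc4c(=O)c3O)c2)cc1` gives 7110 nM. Compound 2 `Cc1ccccc1C(=O)Nc1cccc(-c2oc3cc(-c4ccc(F)cc4)ccc3c(=O)c2O)c1` gives 9900 nM. Compound 3 `O=C(Nc1cccc(-c2oc3cc(-c4ccc(F)cc4)ccc3c(=O)c2O)c1)c1cccc(F)c1` gives 6590 nM, the lowest of the three numbers, although its gaps to the other two lie within the scatter: a 1.1-fold lower number from compound 1 to compound 3 (0.03 log units; within the scatter) and a 1.5-fold lower number from compound 2 to compound 3 (0.18 log units; within the scatter). Together with a 1.4-fold higher number from compound 1 to compound 2 (0.14 log units; within the scatter), these steps show that exchanging the aryl group on the carbonyl carbon among these three variants has not moved the number beyond the scatter.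

Compound 4 `CCCc1ccc(C(=O)Nc2cccc(-c3oc4cc(-c5ccc(F)cc5)ccc4c(=O)c3O)c2)cc1` has not yet been measured. It differs from compound 3 in one place: 4-propylphenyl in place of 3-fluorophenyl on a carbonyl carbon. The change falls at the same spot as the three measured steps, each of which stayed within the scatter. The entering group carries more heavy atoms than any of the three groups already tried, which calls for some caution, but the data offer no reason to expect a large shift in either direction. For this change the expected step is a 1.0-fold lower number from compound 3 to compound 4 (0.01 log units; within the scatter), meaning no movement beyond the scatter. In this assay compound 4 is estimated at 6500 nM, with a range from 2500 nM to 17000 nM.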

Compound 4, half-maximal inhibitory concentration: 15400 nM
Compound 4: middle estimate off by 2.4-fold (0.37 log units), on the low side, and the stated range covers the measured number.
By their numbers in this assay, from the lowest: compounds 3, 1, 2 and 4 (each within the scatter of the next, the first and the last beyond it).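

Within the data shown here, this position is less indifferent than the first three compounds suggested: in this assay the exchange of 3-fluorophenyl for 4-propylphenyl on the carbonyl carbon gives a 2.3-fold higher number from compound 3 to compound 4 (0.37 log units; beyond the scatter) as the first modest step here that clears the scatter. The pair that isolates the chain is compound 1 and compound 4, where ethyl stands in place of hydrogen on a saturated chain carbon bound to an aromatic carbon, and this single change gives a 2.2-fold higher number from compound 1 to compound 4 (0.34 log units; beyond the scatter) as a second modest step, so lengthening the chain alone is enough to raise the number. Compound 2 goes against a clean separation, since a 1.6-fold higher number from compound 2 to compound 4 (0.19 log units; within the scatter) leaves that pair unresolved, and nothing measured here explains the shift.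

As far as these compounds go, what remains open is whether a longer chain such as butyl or hexyl would raise the number further, and whether 4-ethylphenyl would fall between the methyl and propyl cases. Also open, from the compounds shown here alone, is how an amine or a carboxylic acid at the end of the chain would behave on the same aryl group.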